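This account rests on a few compounds, and the source may have more. Where it says the series, first, only, none or still open, it means among the compounds named here.

Measured so far in an assay on Prostate gland for inhibition of steroid 5-alpha-reductase (Rattus norvegicus); a lower number here means a stronger inhibitor, a higher number a weaker inhibitor:
compound 1 `CCCn1ccc2cc(/C(C)=C/C(=O)Nc3ccccc3OCCCC(=O)O)ccc21` gives 190 nM
compound 2 `CCCCn1ccc2cc(/C(C)=C/C(=O)Nc3ccccc3OCCCC(=O)O)ccc21` gives 43 nM

Compound 1 stands as the higher of the two numbers in this assay; its nearest neighbour is compound 2, reached by a 4.4-fold lower number from compound 1 to compound 2 (0.65 log units; beyond the scatter).

The step to be followed leads from compound 1 to compound 3 `CCCCCn1ccc2cc(/C(C)=C/C(=O)Nc3ccccc3OCCCC(=O)O)ccc21`. The change is ethyl in place of hydrogen on a saturated chain carbon, three bonds along the chain from an aromatic nitrogen. It is the same kind of chain lengthening as the measured step, carried one unit further, so that the propyl of compound 1 becomes pentyl instead of the butyl of compound 2.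

Among the measured compounds shown here, only one measured step bears on this, a 4.4-fold lower number from compound 1 to compound 2 (0.65 log units; beyond the scatter), which is modest but beyond the scatter. Whether a further unit continues that trend or levels off cannot be read from two compounds. The expectation is that compound 3 lies at or somewhat past compound 2, so a step of a 7.6-fold lower number from compound 1 to compound 3 (0.88 log units; beyond the scatter) is expected. The estimate for compound 3 in this assay is 25 nM, with a range from 8 nM to 80 nM.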

Compound 3, half-maximal inhibitory concentration: 23 nM
Compound 3: the middle estimate sits 1.1-fold (0.04 log units) above what was measured; measured number inside the range.
By their numbers in this assay, from the lowest: compounds 3 and 2 (each within the scatter of the next); then compound 1.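

Taking the chain from propyl to pentyl in this assay lowers the number beyond the scatter (an 8.3-fold lower number from compound 1 to compound 3 (0.92 log units; beyond the scatter)), so the drop first seen at butyl is kept when the chain grows by a further unit. The added methyl on butyl gives a step within the scatter (a 1.9-fold lower number from compound 2 to compound 3 (0.27 log units; within the scatter)), so compound 2 and compound 3 cannot be told apart, and no further gain past butyl can be claimed from these compounds. Nothing available explains this levelling of the series.

Going by these compounds, whether a longer chain such as hexyl holds this level or gives it up remains open. Also open, on these data alone, is whether a branched chain, or a chain ending in a hydroxyl, an amine or a phenyl ring, is tolerated at this position.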